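The compounds below may be only part of what the source reports. "The series", "measured", "known", "first", "only" and "open" are said of these compounds alone.

Compound 3 `COc1cccc(CN2CCC(C(=O)Nc3cc(Cl)c(N)cc3OC)CC2)c1` is one of three compounds built on a shared core. In a functional assay on the whole organism for antagonist activity, with Mus musculus as the target (on this read-out higher numbers stand for an effect only at larger amounts of compound and lower numbers for an effect already at smaller amounts), compound 3 gives > 4 mg/kg, which is a limit of the assay and not a number. Compound 1 `COc1cc(N)c(Cl)cc1NC(=O)C1CCN(Cc2cccc(C#N)c2)CC1` gives > 4 mg/kg, also a limit. Compound 2 `CCCCCN1CCC(C(=O)Nc2cc(Cl)c(N)cc2OC)CC1` gives > 10 mg/kg, again a limit. Compound 3 stands at the limit of > 4 mg/kg in this assay, at which 2 of the 3 values shown sit. Compound 2 stands at the limit of > 10 mg/kg in this assay, at which 1 of the 3 values shown sits. Compound 4 `COc1cc(N)c(Cl)cc1NC(=O)C1CCN(CC2CCCCC2)CC1` differs from compound 3 by cyclohexyl in place of 3-methoxyphenyl on a saturated chain carbon bound to an amine nitrogen in a ring. The steps bearing on this change, a step that the two limits leave unreadable from compound 2 to compound 3 and a step that the two limits leave unreadable from compound 1 to compound 2, had no readable size, and neither did a step that the two limits leave unreadable from compound 1 to compound 3. Without a readable step, no direction beyond the scatter is expected in this assay. Compound 4 is estimated at 8 mg/kg, within 3 mg/kg to 30 mg/kg. The expected step is a step that the limit leaves unreadable from compound 3 to compound 4.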

Compound 4, dose for half-maximal effect: 2.9 mg/kg
Compound 4: the middle estimate sits 2.8-fold (0.44 log units) above what was measured; measured number outside the range, below it.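

Of the four compounds shown, only compound 4 gives a number rather than a limit in this assay, so cyclohexyl at this saturated chain carbon bound to an amine nitrogen in a ring gives the first readable effect. Against butyl, the change gives an at least 3.4-fold lower number from compound 2 to compound 4 (0.53 log units; beyond the scatter), while against 3-methoxyphenyl it gives an at least 1.3-fold lower number from compound 3 to compound 4 (0.13 log units; that floor lies within the scatter), and against 3-cyanophenyl it gives an at least 1.3-fold lower number from compound 1 to compound 4 (0.13 log units; that floor lies within the scatter). The steps among the three earlier compounds cannot be read, and nothing shown here accounts for the result.

From the compounds shown here alone, how far compound 1 and compound 3 truly lie from compound 4 remains open. Also open, going by these compounds, is whether cyclopentyl at this place would give a number too.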